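The source may report more compounds than this note shows. Statements on the series, on what has been measured and on what is new or still open speak of the compounds shown alone.

Compound 1 `CC(C)COC(=O)Nc1ccc([Se][Se]c2ccc(NC(=O)OCC(C)C)cc2)cc1` gives 42700 nM in an ADME assay on BEAS-2B cells (Homo sapiens) for cytotoxicity, read by MTT assay, with a stated time of 72 h; a higher number here means a weaker inhibitor of growth, a lower number a stronger inhibitor of growth.
Compound 2 `CCCCOC(=O)Nc1ccc([Se]C#N)cc1` gives 12200 nM in this assay.
Compound 3 `N#C[Se]c1ccc(NC(=O)Oc2ccc(F)cc2)cc1` gives 45600 nM in this assay.

Among these three, compound 2 gives the lowest number, and both compound 1 and compound 3 lie beyond the usual scatter above it. Compound 4 `N#C[Se]c1ccc(NC(=O)OCc2ccccc2)cc1` differs from compound 2 by phenyl in place of propyl on a saturated chain carbon bound to an oxygen next to a carbonyl group. For the measured compounds named here, no pair of measured compounds separated by a single change is available here, so the size of this step can only be judged from the spread of the three numbers. A modest rise, or no change beyond the scatter, is expected, and the estimated step of a 1.5-fold higher number from compound 2 to compound 4 (0.17 log units; within the scatter) reflects that. Compound 4 is therefore expected to give 18000 nM, with a range from 7000 nM to 45000 nM.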

Compound 4, concentration for total growth inhibition: 34400 nM
Compound 4: middle estimate off by 1.9-fold (0.28 log units), on the low side, and the stated range covers the measured number.
By their numbers in this assay, from the lowest: compound 2; then compounds 4, 1 and 3 (each within the scatter of the next).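

In this assay, for the compounds shown here, the change from propyl to phenyl on a saturated chain carbon bound to an oxygen next to a carbonyl group gives a 2.8-fold higher number from compound 2 to compound 4 (0.45 log units; beyond the scatter) as the first single change that can be read here. It shows that this position is sensitive to the group it carries, with phenyl giving weaker growth inhibition than propyl. Nothing measured here accounts for this step. The compounds shown leave open whether a cyclohexyl ring, a longer chain or an amine at this place would give a lower or a higher number. They therefore cannot separate the effect of the aromatic ring from that of the added carbons.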